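Configuration at two ring carbons: compound 2 to compound 3

The source may report more compounds than this note shows. Statements on the series, on what has been measured and on what is new or still open speak of the compounds shown alone.

Values from an ADME assay on Caco-2 cells (Homo sapiens) for permeability, read by LC-MS, in the apical to basolateral direction, with a stated time of 60 min, at pH 6.5 (a lower number here means that the compound crosses the layer more slowly, a higher number that the compound crosses the layer faster), are as follows.
Compound 1 (`CC(C)(C)[C@@H](O)C(=O)N1C[C@@H]2C[C@@H]2[C@H]1C(=O)NCc1cc(Cl)ccc1-n1cnnn1`) gives 17 10^-6 cm/s
Compound 2 (`O=C(NCc1cc(Cl)ccc1-n1cnnn1)[C@@H]1[C@H]2C[C@H]2CN1C(=O)[C@H](O)c1ccccc1`) gives 12 10^-6 cm/s

For the measured compounds named here, compound 2 lies within the scatter of compound 1, the only other measured compound, so it holds no distinct place. Compound 3 (`O=C(NCc1cc(Cl)ccc1-n1cnnn1)[C@@H]1[C@@H]2C[C@@H]2CN1C(=O)[C@H](O)c1ccccc1`) has the same atoms and bonds as compound 2 (the two compounds have the same atoms and bonds and differ only in configuration as drawn: 2 of 4 stereo elements differ; a stereocentre at a saturated ring carbon is drawn S in compound 2 and R in compound 3; a stereocentre at a saturated ring carbon is drawn R in compound 2 and S in compound 3). Going by the values given here, the one measured step (a 1.4-fold lower number from compound 1 to compound 2 (0.15 log units; within the scatter)) puts phenyl in place of tert-butyl and changes no configuration, so it bears only indirectly on the size of the step to come. Among the compounds with values here, no measured pair shows the effect of configuration at these ring carbons in this assay for this series. No step beyond the scatter is expected, in either direction, though this rests on little evidence. The expected step is small (a 1.1-fold lower number from compound 2 to compound 3 (0.04 log units; within the scatter)). For compound 3 the estimated value is 11 10^-6 cm/s with an expected range from 5 10^-6 cm/s to 22 10^-6 cm/s in this series.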

Compound 3, apparent permeability: 2.2 10^-6 cm/s
For compound 3 the middle estimate is 5.0-fold (0.70 log units) above the measured one; measured number outside the range, below it.
By their numbers in this assay, from the lowest: compound 3; then compounds 2 and 1 (each within the scatter of the next).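

In this assay, for the compounds shown here, the change in configuration at two saturated ring carbons gives a 5.5-fold lower number from compound 2 to compound 3 (0.74 log units; beyond the scatter), the first step beyond the scatter. The earlier exchange of tert-butyl for phenyl, a 1.4-fold lower number from compound 1 to compound 2 (0.15 log units; within the scatter), gave no sign that this part of the core could matter so much, so the drawn configuration at these ring carbons is now a variable to track in this assay. The step can be assigned to configuration alone, because nothing else separates the two structures: the fact that compounds 2 and 3 differ only in the configuration as drawn

Still open, as far as these compounds go, is whether one of the two ring carbons accounts for the step alone, and whether the same step appears with tert-butyl in place of phenyl. Also open, from the compounds shown here alone, is whether it persists with a cyclohexyl group or an amine at that place.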